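Swapping methoxy for diethylamino on compound 2

The source may hold more compounds than are shown below. What is called first, only, known or untested is meant among the compounds shown, and "the series" means these compounds.

In a functional assay on SMMC-7721 cells (Homo sapiens) for antiproliferative activity, read by MTT assay, with a stated time of 48 h (a lower number here means a stronger inhibitor, a higher number a weaker inhibitor), compound 2 (`COC/C1=C/C[C@](C)(CCC=C(C)C)/C=C/[C@@H](OC(=O)C=C(C)C)[C@](C)(O)/C=C/C1=O`) gives 11000 nM. Compound 1 (`COC/C1=C/C[C@](C)(CCC=C(C)C)/C=C/[C@@H](OC(=O)C=C(C)C)[C@](C)(OC)/C=C/C1=O`) gives 9380 nM, and the two are level: the measured step is a 1.2-fold higher number from compound 1 to compound 2 (0.07 log units; within the scatter). Compound 3 (`C=C1/C=C/C(=O)/C(CO)=C\C[C@](C)(CCC=C(C)C)/C=C/[C@H]1OC(=O)C=C(C)C`) gives 4300 nM, a lower number than compound 2 shows, so compound 2 sits at the upper end of these results.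

Compound 4 (`CCN(CC)C/C1=C/C[C@](C)(CCC=C(C)C)/C=C/[C@@H](OC(=O)C=C(C)C)[C@](C)(O)/C=C/C1=O`) differs from compound 2 by one change, diethylamino in place of methoxy on a saturated chain carbon bound to a double-bonded ring carbon.

For the measured compounds named here, no measured step covers this swap. The step from compound 1 concerns a different oxygen, and compound 3 differs from compound 2 in more than one place, so its value only suggests how far numbers spread in this family. The data therefore favour no direction, and only a modest shift is expected. The estimated step is a 1.4-fold lower number from compound 2 to compound 4 (0.14 log units; within the scatter). For compound 4, the expected value is 8000 nM, with an estimated range from 2500 nM to 25000 nM.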

Compound 4, half-maximal inhibitory concentration: 570 nM
For compound 4 the middle estimate is 14-fold (1.15 log units) above the measured one; measured number below the stated range.
By their numbers in this assay, from the lowest: compound 4; then compound 3; then compounds 1 and 2 (each within the scatter of the next).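

For the compounds shown here, until now, the only measured step between two compounds touched a different oxygen and stayed within the scatter, so nothing showed how much this part of the molecule could matter. In this assay the swap of methoxy for diethylamino gives a 19-fold lower number from compound 2 to compound 4 (1.29 log units; beyond the scatter) and so shows that a saturated chain carbon bound to a double-bonded ring carbon is a place where a single change can move the number far. No evidence here explains why this swap lowers the number so much.

The compounds shown leave open whether the nitrogen or the added carbons go with the lower number, and a pentyl chain on the same carbon would help to tell these apart. Going by these compounds, how a dimethylamino group or a morpholine ring would read at this place also remains open.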